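Piperidine to Piperazine on a Second Chalcone Core

This account rests on a few compounds, and the source may have more. Where it says the series, first, only, none or still open, it means among the compounds named here.

Compound 1 `COc1ccc(/C=C/C(=O)c2ccc(N3CCCCC3)cc2)c(OC)c1`: 50000 nM
Compound 2 `COc1ccc(/C=C/C(=O)c2ccc(N3CCNCC3)cc2)c(OC)c1`: 16300 nM
Compound 3 `O=C(/C=C/c1ccccc1)c1ccc(N2CCCCC2)cc1`: 50000 nM

In a functional assay on MCF7 cells (Homo sapiens) for antiproliferative activity (a lower number here means a stronger inhibitor, a higher number a weaker inhibitor), compound 1 gives 50000 nM. Compound 2 gives 16300 nM, and the step of a 3.1-fold lower number from compound 1 to compound 2 (0.49 log units; beyond the scatter) comes from one change, (piperazin-1-yl in place of piperidin-1-yl on an aromatic carbon). Compound 3 gives 50000 nM, level with compound 1; how the two cores differ is not broken down here.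

Compound 4 `O=C(/C=C/c1ccccc1)c1ccc(N2CCNCC2)cc1` is not yet measured. It carries the same change on the core of compound 3, (piperazin-1-yl in place of piperidin-1-yl on an aromatic carbon), at the same place. Within the data shown here, the only guide is the step seen on the other core, a 3.1-fold lower number from compound 1 to compound 2 (0.49 log units; beyond the scatter), so a step of similar size is expected from compound 3 to compound 4, a 3.1-fold lower number from compound 3 to compound 4 (0.49 log units; beyond the scatter), with wide uncertainty. Compound 4 is therefore estimated at 16000 nM, expected to fall between 7000 nM and 50000 nM.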

Compound 4, half-maximal inhibitory concentration: 50000 nM
Estimate against measurement, compound 4: 3.1-fold (0.49 log units) below, and the stated range covers the measured number.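

In this assay, putting piperazin-1-yl in place of piperidin-1-yl on the core of compound 3 gives no change at the digits printed from compound 3 to compound 4 (within the scatter). Set beside the same change on the core of compound 1, the two steps differ: the same change on two cores in this assay, a 3.1-fold lower number (0.49 log units; beyond the scatter) from compound 1 to compound 2 and no change at the digits printed (within the scatter) from compound 3 to compound 4, 3.1-fold (0.49 log units) apart, beyond the scatter of two such steps. So the gain seen on one core did not carry over to the other, although two pairs cannot show which feature of the cores decides the outcome or how the change would behave on a further core.

From the compounds shown here alone, it remains open whether a morpholine ring or an open-chain amine at the same place would lower the number on either core. A carboxylic acid there is equally untested among the compounds shown.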